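This account rests on a few compounds, and the source may have more. Where it says the series, first, only, none or still open, it means among the compounds named here.

Compounds measured in a functional assay on SK-MEL-5 cells (Homo sapiens) for inhibition, read by sulforhodamine B assay, with a stated time of 48 h; on this read-out higher numbers stand for weaker inhibition of growth and lower numbers for stronger inhibition of growth:
compound 1 `COc1cc(-c2nn(-c3cccc(NC(=O)Nc4cccc(C(F)(F)F)c4)c3)cc2-c2ccncc2)ccc1Cl` — 720 nM
compound 2 `COc1cc(-c2nn(-c3cccc(NC(=O)Nc4ccc(Cl)c(C(F)(F)F)c4)c3)cc2-c2ccncc2)ccc1Cl` — 818 nM

Compound 2 carries the higher of the two numbers, yet the gap to compound 1 is small: the step of a 1.1-fold higher number from compound 1 to compound 2 (0.06 log units; within the scatter) lies within the scatter, so the two compounds are not distinguished by this assay.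

Compound 3 `COc1cc(-c2nn(-c3cccc(NC(=O)c4ccccc4)c3)cc2-c2ccncc2)ccc1Cl` is not yet measured. It differs from compound 2 in one place: phenyl in place of (4-chloro-3-(trifluoromethyl)phenyl)amino on a carbonyl carbon. Among the measured compounds shown here, the one measured step concerns only a chloro on the aromatic ring that leaves here, so no measured step bears on the change from a urea to a benzamide. The change removes a hydrogen-bond donor and the whole substituted ring, and nothing in the series shows how the assay responds to such a change. Compound 3 is therefore expected to give a weaker result, with wide uncertainty: an estimated 3000 nM in this assay, within 800 nM to 12000 nM, which means an expected step of a 3.7-fold higher number from compound 2 to compound 3 (0.56 log units; beyond the scatter).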

Compound 3, concentration for 50% growth inhibition: 319 nM
Beside the measured number, compound 3's estimate is 9.4-fold (0.97 log units) above it, outside the stated range (below it).
By their numbers in this assay, from the lowest: compound 3; then compounds 1 and 2 (each within the scatter of the next).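

In this assay the substituted arylamino part on the carbonyl carbon proves dispensable for growth inhibition: exchanging (4-chloro-3-(trifluoromethyl)phenyl)amino for phenyl gives a 2.6-fold lower number from compound 2 to compound 3 (0.41 log units; beyond the scatter) and exchanging (3-(trifluoromethyl)phenyl)amino for phenyl gives a 2.3-fold lower number from compound 1 to compound 3 (0.35 log units; beyond the scatter) in the same direction. The earlier chloro step showed only that one substituent on the leaving ring made no readable difference, whereas these modest steps show that this position tolerates a change from urea to benzamide, with the smaller group and no loss of inhibition of growth. Nothing available on the compounds explains why the benzamide gives the lower number.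

The compounds shown do not separate the loss of the amino nitrogen from the loss of the ring substituents, which a plain phenylamino group on the same carbonyl carbon would address. Going by these compounds, how the benzamide phenyl responds to substitution, for example by a methoxy group, a dimethylamino group or a carboxylic acid, also remains open.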